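This account rests on a few compounds, and the source may have more. Where it says the series, first, only, none or still open, it means among the compounds named here.

Series notes. Compound 1 `Cn1nnnc1SCC(=O)Nc1ccc(-c2nc(-c3ccccc3)c(-c3ccccc3)n2C)cc1`, compound 2 `Cc1nnc(SCC(=O)Nc2ccc(-c3nc(-c4ccccc4)c(-c4ccccc4)n3C)cc2)s1` and compound 3 `CCN1CCN(CC(=O)Nc2ccc(-c3nc(-c4ccccc4)c(-c4ccccc4)n3C)cc2)CC1` share one core and differ only in the chain on the amide. In a functional assay on MCF7 cells (Homo sapiens) for cytotoxicity, read by MTT assay, with a stated time of 24 h, tested at 80 ug/mL (a lower number here means a weaker effect, a higher number a stronger effect of the compound at the concentration tested), compound 1 gives 77.7%, compound 2 gives 85.2% and compound 3 gives 46.3%. Compound 3 stands lowest of the three: a number 31.4 percentage points lower from compound 1 to compound 3 (beyond the scatter) and a number 38.9 percentage points lower from compound 2 to compound 3 (beyond the scatter), whereas a number 7.5 percentage points higher from compound 1 to compound 2 (within the scatter). Compound 4 `Cn1c(-c2ccc(NC(=O)CN3CCN(Cc4ccccc4)CC3)cc2)nc(-c2ccccc2)c1-c1ccccc1` is the next step from compound 3: phenyl in place of methyl on a saturated chain carbon bound to an amine nitrogen in a ring. Going by the values given here, none of the measured steps touches that place; all three exchange the group on the saturated chain carbon bound to the carbonyl carbon, so they bear only loosely on this change. No step beyond the scatter is therefore expected in this assay, in either direction. Compound 4 is estimated at 52%, range 35% to 70%, an expected step of a number 5.7 percentage points higher from compound 3 to compound 4 (within the scatter).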

Compound 4, a percentage reported as activity, at one concentration (the size of the read-out at that concentration, not a potency): 49.5%
The estimate for compound 4 lay 2.5 percentage points above the measured number; the range from low to high includes it.
By their numbers in this assay, from the lowest: compounds 3 and 4 (each within the scatter of the next); then compounds 1 and 2 (each within the scatter of the next).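

In this assay, phenyl in place of methyl on a saturated chain carbon bound to an amine nitrogen in a ring gives a number 3.2 percentage points higher from compound 3 to compound 4 (within the scatter) and is the first change shown at this position. Read one bond further out, ethyl to benzyl adds a six-membered aromatic ring without a step beyond the scatter, so this single concentration does not separate compound 3 from compound 4. No measured evidence bears on this result. Open, going by these compounds, is how a hydroxyethyl group or a longer alkyl chain would read at this place, and whether other concentrations would separate compound 3 from compound 4.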